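Swapping cyclopentyl for an open ether chain

The source may report more compounds than this note shows. Statements on the series, on what has been measured and on what is new or still open speak of the compounds shown alone.

Compound 1 `CCS(=O)(=O)c1ccc(Oc2cc(O[C@@H](C)CO)cc(-c3nccc(=O)[nH]3)c2)cc1`: < 25.4 mL/min/kg, a limit of the assay
Compound 2 `CCC(CC)Oc1cc(Oc2cnc(C(=O)N(C)C)nc2)cc(-c2nccc(=O)[nH]2)c1`: 91 mL/min/kg
Compound 3 `CN(C)C(=O)c1ncc(Oc2cc(OC3CCCC3)cc(-c3nccc(=O)[nH]3)c2)cn1`: 106 mL/min/kg

In an ADME assay on microsomes from liver (Rattus norvegicus) for metabolic stability (a higher number here means faster removal of the compound, a lower number slower removal), only compound 2 and compound 3 have actual numbers, and these two cannot be told apart. Compound 1 has a limit and not a number.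

Compound 4 `COC[C@H](C)Oc1cc(Oc2cnc(C(=O)N(C)C)nc2)cc(-c2nccc(=O)[nH]2)c1` keeps the rest of compound 3 and changes one group: 1-(methoxymethyl)ethyl in place of cyclopentyl on an oxygen on an aromatic ring. The entering 1-(methoxymethyl)ethyl has no ring, and it brings a hydrogen-bond acceptor and a defined stereocentre.

Among the compounds with values here, only one measured step touches this place on the structure: a 1.2-fold higher number from compound 2 to compound 3 (0.07 log units; within the scatter). That step exchanged cyclopentyl with pentan-3-yl, and neither of those groups holds an oxygen, so it covers only part of the present change. It offers no support for a large move, and the direction remains uncertain. A modest fall is expected, with the estimated step being a 1.8-fold lower number from compound 3 to compound 4 (0.25 log units; within the scatter). For compound 4 the expected clearance is 60 mL/min/kg, with an estimated range of 30 mL/min/kg to 110 mL/min/kg.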

Compound 4, clearance: 38 mL/min/kg
Beside the measured number, compound 4's estimate is 1.6-fold (0.20 log units) above it; the range from low to high includes it.
By their numbers in this assay, from the lowest: compound 4; then compounds 2 and 3 (each within the scatter of the next). At a limit, below all of these: compound 1.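

In this assay, within the data shown here, the only earlier step at this place, a 1.2-fold higher number from compound 2 to compound 3 (0.07 log units; within the scatter), joined two groups made of carbon alone and showed no readable change. With 1-(methoxymethyl)ethyl on the oxygen the place now gives a move beyond the scatter against both of those groups: a 2.8-fold lower number from compound 3 to compound 4 (0.45 log units; beyond the scatter), and a 2.4-fold lower number from compound 2 to compound 4 (0.38 log units; beyond the scatter). Pentan-3-yl has no ring either, so having no ring does not by itself go with the lower number; among these three groups, the lower number goes with the one holding an oxygen and a defined stereocentre.

On these data alone, whether the oxygen, the stereocentre or both go with the fall stays open, as does what the opposite stereoisomer, a free hydroxyl in place of the methoxy end or an amine would give here. Compound 1 differs in more than one place and carries a limit, so it cannot settle this: the limit of < 25.4 mL/min/kg in this assay, at which 1 of the 4 values shown sits.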